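Pyridine to pyrimidine on the piperazine of compound 2

This account rests on a few compounds, and the source may have more. Where it says the series, first, only, none or still open, it means among the compounds named here.

Compound 2 `Cc1cccc(NC(=O)CCN2CCN(c3ccccn3)CC2)c1` gives 612 nM in a functional assay on cells for agonist activity at D(4) dopamine receptor (Homo sapiens), read by TR-FRET and cAMP accumulation, with a stated time of 30 min; a higher number here means that more compound is needed for the effect, a lower number that less compound is needed. For the measured compounds named here, that is the lowest of the two numbers measured, but its only neighbour, compound 1 `O=C(CN1CCN(c2ccccn2)CC1)Nc1cccnc1`, gives 1080 nM in this assay, and the two numbers lie within the usual scatter of each other, so no order between them can be read. The new entry is compound 3 `Cc1cccc(NC(=O)CCN2CCN(c3ncccn3)CC2)c1`, which has not yet been measured in this assay. It differs from compound 2 in one place: pyrimidin-2-yl in place of pyridin-2-yl on an amine nitrogen in a ring. Going by the values given here, no measured pair shows what this exchange does to the read-out, and the two measured numbers give no direction for it. Compound 3 is therefore expected to stay close to compound 2, with a step of a 1.5-fold higher number from compound 2 to compound 3 (0.17 log units; within the scatter) that may not exceed the scatter. The half-maximal effective concentration of compound 3 is estimated at 900 nM, within a range from 250 nM to 3500 nM.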

Compound 3, half-maximal effective concentration: 568 nM
The estimate for compound 3 lay 1.6-fold (0.20 log units) above the measured number, and the stated range covers the measured number.
By their numbers in this assay, from the lowest: compounds 3, 2 and 1 (each within the scatter of the next).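

In this assay, pyrimidin-2-yl in place of pyridin-2-yl on the amine nitrogen in a ring gives a 1.1-fold lower number from compound 2 to compound 3 (0.03 log units; within the scatter) and so lies within the scatter, which means compound 2 and compound 3 cannot be told apart. For the compounds shown here, this is the first measured pair at this position, and it shows that the ring here can carry 2 hetero atoms instead of 1, and 2 hydrogen-bond acceptors instead of 1, with no readable effect on the number. No measurement among those shown offers an explanation for this result. The compounds shown leave open whether a phenyl or pyrazin-2-yl ring on the same nitrogen would give a step beyond the scatter. They also leave open whether a methoxy group on the pyrimidin-2-yl ring would do so, and whether the same exchange on the core of compound 1 would behave alike.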